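The source may hold more compounds than are shown below. What is called first, only, known or untested is meant among the compounds shown, and "the series" means these compounds.

Compound 1 `COc1ccc(C(=O)/C=C/c2ccc3ccccc3c2)c2c1C=CC(C)(C)O2`: 7650 nM
Compound 2 `CCN(CC)c1ccc(/C=C/C(=O)c2ccc(OC)c3c2OC(C)(C)C=C3)cc1`: 610 nM
Compound 3 `COc1ccc(C(=O)/C=C/c2ccc(-n3ccnc3)cc2)c2c1C=CC(C)(C)O2`: 7200 nM

In a functional assay on SK-OV-3 cells (Homo sapiens) for antiproliferative activity, read by MTT assay, with a stated time of 24 h (on this read-out higher numbers stand for weaker inhibition and lower numbers for stronger inhibition), compound 3 gives 7200 nM, the second highest of the three numbers. Compound 1 gives 7650 nM, within the scatter of compound 3, whereas compound 2 gives 610 nM, a lower number beyond the scatter. Going by the values given here, the only measured step at the same aromatic carbon is a 12-fold higher number from compound 2 to compound 3 (1.07 log units; beyond the scatter), which shows that the group at this position can matter greatly. Compound 4 `COc1ccc(C(=O)/C=C/c2ccc(Cl)cc2)c2c1C=CC(C)(C)O2` differs from compound 3 by chloro in place of 1H-imidazol-1-yl on an aromatic carbon. Among the compounds with values here, no measured step involves chloro, so there is no direct precedent. Compound 4 is expected to stay close to compound 3, with an expected step of a 1.0-fold lower number from compound 3 to compound 4 (0.01 log units; within the scatter), within the scatter. Compound 4 is therefore estimated at 7000 nM, in the range 2500 nM to 20000 nM.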

Compound 4, half-maximal inhibitory concentration: > 10000 nM
Compound 4 gave a limit, no number (the forecaster's own chance of this, stated with the estimate: 10%); middle value at least 1.4-fold (0.15 log units) away from the limit.
By their numbers in this assay, from the lowest: compound 2; then compounds 3 and 1 (each within the scatter of the next). At a limit, above all of these: compound 4.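

Compound 4 gives only a limit, not a number, in this assay: the limit of > 10000 nM in this assay, at which 1 of the 4 values shown sits. At this aromatic carbon, chloro also stands far from diethylamino, with an at least 16-fold higher number from compound 2 to compound 4 (1.21 log units; beyond the scatter), a second large step at this position. Against 1H-imidazol-1-yl, the change reads only as an at least 1.3-fold higher number from compound 3 to compound 4 (0.14 log units; that floor lies within the scatter), so this step does not separate chloro from 1H-imidazol-1-yl. The compounds shown leave open whether the low number of compound 2 is particular to diethylamino or would also appear with a smaller amine such as dimethylamino, or with a longer chain on the nitrogen.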